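The source may hold more compounds than are shown below. What is called first, only, known or untested is meant among the compounds shown, and "the series" means these compounds.

Measured so far:
Compound 1 `CC(C)(NC(=O)[C@@H](S)CCc1ccccc1)C(=O)N1CCCC1C(=O)O` — 46 nM
Compound 2 `CC[C@@H](C)[C@H](NC(=O)[C@@H](S)Cc1ccccc1)C(=O)N1CCCC1C(=O)O` — 24 nM

Of the compounds shown here, two have been tested in an assay on isolated protein for inhibition of Neprilysin (Oryctolagus cuniculus); a higher number here means a weaker inhibitor, a lower number a stronger inhibitor. Compound 1 gives 46 nM in this assay, and compound 2 gives 24 nM. Compound 2 has the lower of the two numbers, but the gap to compound 1 lies within the usual scatter of repeated measurements, so the two cannot be told apart on these values. The two structures also differ in more than one place, so no single step can be read from them.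

Compound 3 `CC[C@@H](C)[C@H](NC(=O)[C@@H](S)c1ccccc1)C(=O)N1CCCC1C(=O)O` is not yet measured. It differs from compound 2 in one place: phenyl in place of benzyl on a saturated chain carbon bound to a carbonyl carbon and a sulfur. Within the data shown here, no measured pair shows a change of this kind, so the expectation rests on the change itself. In this series the aromatic ring is drawn one chain carbon closer to the carbonyl and the sulfur. The estimate for compound 3 in this assay is a weaker inhibitor than compound 2, with the step from a 13-fold higher number from compound 2 to compound 3 (1.10 log units; beyond the scatter) expected to lie beyond the scatter, giving an expected value of 300 nM, with a range from 60 nM to 1500 nM.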

Compound 3, half-maximal inhibitory concentration: 130 nM
Compound 3: middle estimate off by 2.3-fold (0.36 log units), on the high side; low and high end bracket the measured number.
By their numbers in this assay, from the lowest: compounds 2 and 1 (each within the scatter of the next); then compound 3.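

Among these compounds, the change from benzyl to phenyl is the first single change that can be read: on a saturated chain carbon bound to a carbonyl carbon and a sulfur, this assay shows a 5.4-fold higher number from compound 2 to compound 3 (0.73 log units; beyond the scatter) and this lies beyond the scatter. This position is therefore sensitive to how the aromatic ring is attached, since one chain carbon fewer weakens inhibition, although compound 3 still gives a measurable 130 nM in this assay and the change does not abolish it. Nothing available here bears on why the step has this size.

Compound 1 differs from the other two compounds in more than one place, so its longer chain cannot be compared directly with this step, and the series shown gives no single-change reading of chain length beyond benzyl and phenyl. Also open, from the compounds shown here alone, is how this position would respond to a ring other than phenyl, such as a cyclohexyl or pyridyl group, and whether the same step would appear with a different group in place of the rest of compound 2.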